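Two-aminobenzothiazole series: chain branching and chain length

This account rests on a few compounds, and the source may have more. Where it says the series, first, only, none or still open, it means among the compounds named here.

Compound 1 `CC(C)c1ccc2nc(N)sc2c1` is taken in a functional assay on the whole organism with Rattus norvegicus as the target (a higher number here means that more compound is needed for the effect, a lower number that less compound is needed), where compound 1 gives > 10 mg/kg, a limit of the assay and not a number. Compound 2 `CC(C)(C)c1ccc2nc(N)sc2c1` carries methyl in place of hydrogen on a saturated chain carbon bound to an aromatic carbon and two saturated chain carbons relative to compound 1, and in this assay compound 2 gives 4 mg/kg; the step of an at least 2.5-fold lower number from compound 1 to compound 2 (0.39 log units; beyond the scatter) is recorded. Compound 3 `CCCCCCc1ccc2nc(N)sc2c1` differs from compound 1 in a way that is not broken down here; in this assay compound 3 gives 7 mg/kg, and its values with compound 2 are within the scatter of one another.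

Compound 4 `CCCCCCCc1ccc2nc(N)sc2c1` is not yet measured. It carries methyl in place of hydrogen on a saturated chain carbon, six bonds along the chain from an aromatic carbon relative to compound 3. This is the same kind of change as from compound 1 to compound 2, but the place differs: there, on a saturated chain carbon bound to an aromatic carbon and two saturated chain carbons; here, on a saturated chain carbon six bonds along the chain from an aromatic carbon. The step of a 1.2-fold lower number from compound 3 to compound 4 (0.07 log units; within the scatter) is therefore expected to be small and within the scatter. Compound 4 is expected to give 6 mg/kg in this assay, between 3 mg/kg and 14 mg/kg.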

Compound 4, dose for half-maximal effect: > 10 mg/kg
Compound 4 gave a limit, no number; the forecaster's own chance of this, stated with the estimate: 20%; middle value at least 1.6-fold (0.22 log units) away from the limit.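

In this assay, from the compounds shown here alone, adding the methyl does not give the same outcome on both cores: the same change on two cores in this assay, an at least 2.5-fold lower number (0.39 log units; beyond the scatter) from compound 1 to compound 2 and an at least 1.4-fold higher number (0.15 log units; that floor lies within the scatter) from compound 3 to compound 4, at least 3.5-fold (0.55 log units) apart, beyond the scatter of two such steps Taken alone, the new step, an at least 1.4-fold higher number from compound 3 to compound 4 (0.15 log units; that floor lies within the scatter), gives only a floor, so a rise beyond the scatter is not established for this pair, and the true size of the step stays unknown. The comparison shows that these two pairs differ, but it gives no rule for the series: the change sits at different places on the chain, and neither step has a number at both ends, so the size of the gap also remains open: the limit of > 10 mg/kg in this assay, at which 2 of the 4 values shown sit.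

The compounds shown leave open whether a longer chain, such as octyl, stays at the limit or gives a number. They also leave open how a shorter straight chain, such as butyl, or a chain carrying an amine or a carboxylic acid, would read in this assay.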